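The compounds below may be only part of what the source reports. "The series", "measured", "known", "first", "only" and "open" are said of these compounds alone.

Measured so far in a functional assay on aorta for antagonist activity at Alpha-1D adrenergic receptor (Rattus norvegicus); a lower number here means tighter binding, a higher number weaker binding:
compound 1, `COc1ccccc1N1CCN(CCCNc2ncccc2C(=O)N(C)C)CC1`, gives 20 nM;
compound 2, `CN(C)C(=O)c1cccnc1NCCCN1CCN(c2ccccc2-c2ncco2)CC1`, gives 25.1 nM;
compound 3, `COc1cc(F)ccc1N1CCN(CCCNc2c(C(=O)N(C)C)cnc3c2c(C)nn3C)CC1`, gives 316 nM.

Compound 4, `Cc1nn(C)c2ncc(C(=O)N(C)C)c(NCCCN3CCN(c4ccc(F)cc4-c4ncco4)CC3)c12`, has not been measured. It differs from compound 3 by 1,3-oxazol-2-yl in place of methoxy on an aromatic carbon. The same change, (1,3-oxazol-2-yl in place of methoxy on an aromatic carbon), has one measured example, which reads a 1.3-fold higher number from compound 1 to compound 2 (0.10 log units; within the scatter). The surroundings of the place are not identical: in the step from compound 3 to compound 4 the changed carbon is also meta to a fluoro group, so this is the same kind of change rather than the same one. How the core of compound 1 differs from the core of compound 3 is not broken down here. For the measured compounds named here, since the one measured example of this change gave a 1.3-fold higher number from compound 1 to compound 2 (0.10 log units; within the scatter), a step of similar size is expected from compound 3 to compound 4 in this assay, namely a 1.3-fold higher number from compound 3 to compound 4 (0.10 log units; within the scatter). Compound 4 is therefore estimated at 400 nM, most likely between 200 nM and 900 nM.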

Compound 4, dissociation constant: 200 nM
Estimate against measurement, compound 4: 2.0-fold (0.30 log units) above, within the range that was stated.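

In this assay, 1,3-oxazol-2-yl in place of methoxy gives a 1.6-fold lower number from compound 3 to compound 4 (0.20 log units; within the scatter). Set beside the earlier example, the change carries over from one core to the other with no difference that can be told from the scatter: the same change on two cores in this assay, a 1.3-fold higher number (0.10 log units; within the scatter) from compound 1 to compound 2 and a 1.6-fold lower number (0.20 log units; within the scatter) from compound 3 to compound 4, 2.0-fold (0.30 log units) apart, within the scatter of two such steps This rests on only two pairs, so it does not show that the change would be as quiet on a further core, and it cannot separate any part played by the fluoro group, which only the second pair carries.

Still open, from the compounds shown here alone, is whether a carboxylic acid or an amine in place of methoxy would also leave the number where it stands. Going by these compounds, how this change reads at other receptors also stays open.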